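Fluorine on the N-aryl ring of the lactam series

The source may report more compounds than this note shows. Statements on the series, on what has been measured and on what is new or still open speak of the compounds shown alone.

The series is followed in an in vitro functional assay on HEK293-A cells for positive allosteric modulation of metabotropic glutamate receptor 5 (Homo sapiens), read by FLIPR and calcium flux; a lower number here means that less compound is needed, a higher number that more compound is needed for the effect. Compound 1 `O=C1CC(c2nc(-c3ccccc3)no2)CN1c1ccccc1` gives 350 nM and stands at the lowest of the two numbers obtained so far. Compound 3 `Cc1ccc(N2CC(c3nc(-c4cccc(C)c4)no3)CC2=O)cc1` gives 1300 nM, a higher number than compound 1, with the gap beyond the scatter. Compound 2 `O=c1sc2ccccc2n1Cc1nc(-c2cccc(Cl)c2)no1`, built on a different core, gives only a limit of the assay, > 10000 nM; the note the limit of > 10000 nM in this assay, at which 1 of the 3 values shown sits, records that one of the three values sits at this limit.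

Compound 4 `O=C1CC(c2nc(-c3ccccc3)no2)CN1c1ccc(F)cc1` is not yet measured. It differs from compound 1 in a single place: fluoro in place of hydrogen on an aromatic carbon, on an aromatic carbon of a six-membered aromatic ring of carbon only, para to a large group. Going by the values given here, no pair of measured compounds carries the same change, so nothing in the data shows how such a step behaves in this assay; compound 1 and compound 3 differ in several places at once and give no guide.

The step from compound 1 to compound 4 is expected to be small, a 1.1-fold lower number from compound 1 to compound 4 (0.04 log units; within the scatter), in either direction and within the scatter. For compound 4 the half-maximal effective concentration is estimated at 320 nM, with a range from 120 nM to 900 nM.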

Compound 4, half-maximal effective concentration: 58 nM
The estimate for compound 4 lay 5.5-fold (0.74 log units) above the measured number; the whole stated range lies above it.
By their numbers in this assay, from the lowest: compound 4; then compound 1; then compound 3. At a limit, above all of these: compound 2.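

In this assay, going by these compounds alone, phenyl to 4-fluorophenyl gives a 6.0-fold lower number from compound 1 to compound 4 (0.78 log units; beyond the scatter), the first step that can be read at a single place. It shows that this position, on an aromatic carbon of a six-membered aromatic ring of carbon only and para to a large group, responds to one added fluoro with a clear drop in the compound needed for the effect, something compound 1 and compound 3 could not show, as they differ in several places at once. Nothing in the data bears on what lies behind the size of this step.

One step on one core leaves open whether the gain belongs to fluoro itself or would also appear with another group at the same place, such as chloro, methyl, methoxy or nitrile. Also open, from the compounds shown here alone, are whether fluoro on another carbon of this ring gives a step of similar size, and whether the same change on the other aromatic ring of compound 4 would add to the gain or cancel it.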